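A few compounds are considered here, and "the series" means these few. Any claim that something is new, unique, unknown or untested is made for them only; others in the source may bear on it.

Working notes on the tetrabromo series. Compound 1 `COc1cccc(C(O)CCn2nc3c(Br)c(Br)c(Br)c(Br)c3n2)c1` and compound 2 `OC(CCn1nc2c(Br)c(Br)c(Br)c(Br)c2n1)c1cccc(Cl)c1` share the same core and the same hydroxypropyl linker and differ only on the pendant phenyl. In a functional assay on CCRF-CEM cells (Homo sapiens) for antiproliferative activity, read by MTT assay, with a stated time of 24 h, tested at 12.5 uM (on this read-out higher numbers stand for a weaker effect at the one concentration tested and lower numbers for a stronger effect), compound 1 gives 110%, and compound 2 gives 110%. The one step measured so far, no change at the digits printed from compound 1 to compound 2 (within the scatter), is thus flat; on the numbers shown compound 2 stands level with compound 1, both at the weak end of the read-out, and neither can be called the more active of the two.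

Compound 3 `OC(CCn1nc2c(Br)c(Br)c(Br)c(Br)c2n1)c1ccc(Br)cc1` is the next member, not yet measured. It differs from compound 2 by 4-bromophenyl in place of 3-chlorophenyl on a saturated chain carbon bound to an oxygen on a saturated carbon and a saturated chain carbon. Going by the values given here, no measured step covers this exact exchange; the only step that bears on it at all is the change on the same phenyl from compound 1 to compound 2, which was within the scatter. Nothing in the data points to a direction for another change on that phenyl, so the expected step of a number 2 percentage points lower from compound 2 to compound 3 (within the scatter) is none beyond the scatter. For compound 3 the value in this assay is therefore expected at 108%, within 95% to 120%.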

Compound 3, a percentage reported as activity, at one concentration (the size of the read-out at that concentration, not a potency): 101%
Compound 3: the middle estimate sits 7 percentage points above what was measured; measured number inside the range.
By their numbers in this assay, from the lowest: compounds 3, 1 and 2 (each within the scatter of the next).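

In this assay, 4-bromophenyl in place of 3-chlorophenyl gives a number 9 percentage points lower from compound 2 to compound 3 (within the scatter), and 4-bromophenyl in place of 3-methoxyphenyl gives a number 9 percentage points lower from compound 1 to compound 3 (within the scatter). Going by these compounds alone, this position on the saturated chain carbon bound to an oxygen has now carried three different substituted phenyl groups, including the first with its substituent named at the 4 position, and no step among the three compounds lies beyond the scatter, so the read-out does not yet separate any of these groups from the others. No accompanying data bear on this result.

The exchange from 3-chlorophenyl to 4-bromophenyl alters both the halogen and its place on the ring, so the compounds shown cannot assign any part of the step to either alteration; 3-bromophenyl and 4-chlorophenyl would separate the two. Also open, on these data alone, is whether a phenyl carrying an amine or a carboxylic acid, or a longer chain between the shared core and the phenyl, would move the read-out beyond the scatter at the single concentration tested.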